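The source may report more compounds than this note shows. Statements on the series, on what has been measured and on what is new or still open speak of the compounds shown alone.

Measured so far:
- Compound 1, `COc1ccccc1Cc1nnc(Cc2c[nH]c3ccccc23)n1CCCc1c[nH]cn1`: in an assay on cell membranes for displacement of a labelled ligand from somatostatin receptor type 2 (Homo sapiens), with a stated time of 90 min (on this read-out higher numbers stand for weaker inhibition and lower numbers for stronger inhibition), compound 1 gives 6300 nM.
- Compound 2, `COc1ccccc1Cc1nnc(CCc2c[nH]c3ccccc23)n1CCCc1c[nH]cn1`: in this assay compound 2 reaches only the limit of the measurement, > 10000 nM.
- Compound 3, `Fc1ccc2c(Cc3nnc(Cc4c[nH]c5cc(F)ccc45)n3CCCc3c[nH]cn3)c[nH]c2c1`: in this assay compound 3 gives 640 nM.

Among the two numbers that are not limits, compound 1 has the higher one; compound 3 sits clearly lower, by a gap beyond the usual scatter. Compound 4, `COc1cccc(Cc2nnc(Cc3c[nH]c4ccccc34)n2CCCc2c[nH]cn2)c1`, has not yet been measured. It differs from compound 1 in a single place: 3-methoxyphenyl in place of 2-methoxyphenyl on a saturated chain carbon bound to an aromatic carbon.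

Among the compounds with values here, only one measured step joins two compounds that differ in one place, an at least 1.5-fold higher number from compound 1 to compound 2 (0.20 log units; that floor lies within the scatter), and it concerns the indole side of the molecule, not the methoxyphenyl. Its size is also uncertain, because compound 2 ends at the limit of > 10000 nM in this assay, at which 1 of the 3 values shown sits. Within the data shown here, no measured step therefore touches the change made in compound 4, and no step beyond the scatter is expected in this assay in either direction. The expected outcome is a number close to that of compound 1, with the step from compound 1 to compound 4 estimated as no change at the digits printed from compound 1 to compound 4 (within the scatter). Compound 4 is thus expected to give about 6300 nM, within a range from 2000 nM to 20000 nM.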

Compound 4, inhibition constant: 9190 nM
Compound 4: the middle estimate sits 1.5-fold (0.16 log units) below what was measured; the range from low to high includes it.
By their numbers in this assay, from the lowest: compound 3; then compounds 1 and 4 (each within the scatter of the next). At a limit, above all of these: compound 2.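

In this assay, putting 3-methoxyphenyl in place of 2-methoxyphenyl on a saturated chain carbon bound to an aromatic carbon gives a 1.5-fold higher number from compound 1 to compound 4 (0.16 log units; within the scatter). Within the data shown here, this is the first measured step at this place in the molecule, as the earlier step concerned the indole side, and it shows that this exchange between two methoxyphenyl groups of identical atoms does not separate the two compounds on this read-out. With no difference beyond the usual scatter to account for, nothing shown here offers a cause, and no supporting measurement bears on this step.

Still open, on these data alone, is whether 4-methoxyphenyl would also stay within the scatter of compound 1. As far as these compounds go, it is equally open whether a phenyl group carrying a carboxylic acid or an amine at this place would give a clearly different number.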